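Swapping a Sulfonamide for a Furanamide on a Shared Core

The source may report more compounds than this note shows. Statements on the series, on what has been measured and on what is new or still open speak of the compounds shown alone.

In a functional assay on MV4-11 cells (Homo sapiens) for cytotoxicity, read by MTT assay, with a stated time of 72 h (on this read-out lower numbers stand for stronger inhibition and higher numbers for weaker inhibition), compound 1 `CCCS(=O)(=O)Nc1ccc(-c2cn3c(C(=O)OCC)csc3n2)cc1` gives only a limit, > 20000 nM. Compound 2 `CCOC(=O)c1csc2nc(-c3cccc(NC(=O)CC)c3)cn12` likewise reaches only a limit in this assay, > 20000 nM. Compound 3 `C=CC(=O)Nc1cccc(-c2cn3c(C(=O)OCC)csc3n2)c1` also shows no more than a limit in this assay, > 20000 nM. All three values sit at the limit of > 20000 nM in this assay, at which 3 of the 3 values shown sit, so compound 1 cannot be placed against the other two beyond sharing that limit with them. For the measured compounds named here, the one single-point change among the measured compounds, a step that the two limits leave unreadable from compound 2 to compound 3, is for the same reason unreadable, and no measured step of known size exists in this set.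

Compound 4 `CCOC(=O)c1csc2nc(-c3ccc(NC(=O)c4ccco4)cc3)cn12` is yet to be measured in this assay. It differs from compound 1 by (furan-2-yl)carbonyl in place of propylsulfonyl on a nitrogen on an aromatic ring. Going by the values given here, no measured step bears on this exchange: the only recorded step is unreadable, and every measured value is a limit. Since compound 1 itself sits at the limit of > 20000 nM in this assay, at which 3 of the 3 values shown sit, compound 4 is expected to remain outside the readable range as well. The step from compound 1 to compound 4 is expected to be a step that the limit leaves unreadable from compound 1 to compound 4, which is to say none beyond the scatter. Compound 4 is accordingly estimated at 30000 nM, within 8000 nM to 120000 nM, with a limit rather than a number the more likely outcome.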

Compound 4, half-maximal inhibitory concentration: 9920 nM
For compound 4 the middle estimate is 3.0-fold (0.48 log units) above the measured one, within the range that was stated.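

In this assay, for the compounds shown here, this nitrogen on an aromatic ring gives the first readable number of the set: with (furan-2-yl)carbonyl in place of propylsulfonyl, compound 4 gives 9920 nM. Compound 1 gives only a limit of the assay, > 20000 nM. The exchange therefore reads as an at least 2.0-fold lower number from compound 1 to compound 4 (0.30 log units; that floor lies within the scatter), which is a floor and not a size, and no other number stands in the set to compare it with: the limit of > 20000 nM in this assay, at which 3 of the 4 values shown sit.

The compounds shown leave open whether the number follows the furan ring itself or simply the carbonyl on that nitrogen, a question that a propanoyl or benzoyl group at the same place would bear on. Also open, on these data alone, is how the read-out would respond to a longer chain or an amine on the group that enters, and whether a carboxylic acid in place of the ethyl ester of the shared core would keep the number within the readable range.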